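This account rests on a few compounds, and the source may have more. Where it says the series, first, only, none or still open, it means among the compounds named here.

In a functional assay on 4T1 cells (Mus musculus) for cytotoxicity, read by MTT assay, with a stated time of 48 h (on this read-out lower numbers stand for stronger inhibition and higher numbers for weaker inhibition), compound 1 (`COc1ccc(/C=C/C(=O)/C=C/c2cc3ccccc3nc2Oc2ccccc2)cc1`) gives > 10000 nM, which is a limit of the assay and not a number. Compound 2 (`COc1ccc(/C=C/C(=O)/C=C/c2cc3ccccc3nc2Oc2ccccc2)c(OC)c1`) carries one further methoxy in place of hydrogen on an aromatic carbon, and compound 2 also gives only a limit, > 10000 nM. Among the measured compounds shown here, the only measured step is therefore a step that the two limits leave unreadable from compound 1 to compound 2. Both compounds sit at the limit of > 10000 nM in this assay, at which 2 of the 2 values shown sit, so compound 2 stands at a limit with no readable potency. Compound 3 (`COc1ccc(/C=C/C(=O)/C=C/c2cc3ccccc3nc2Oc2cccc(Cl)c2)c(OC)c1`) turns the phenoxy into 3-chlorophenoxy, with chloro in place of hydrogen on an aromatic carbon. For the measured compounds named here, no measured step tests this change, so the data support no particular size or direction in this assay. The expected change is a step that the limit leaves unreadable from compound 2 to compound 3, an estimate that stays close to the limit. Compound 3 is expected at about 11000 nM, with an estimated range of 3500 nM to 30000 nM.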

Compound 3, half-maximal inhibitory concentration: > 10000 nM
Compound 3 was reported as a limit; the forecaster's own chance of this, stated with the estimate: 65%; the middle value does not contradict the limit.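

In this assay compound 3 gives > 10000 nM, a limit and not a number. No step can be read from compound 2 to compound 3, and compounds 1, 2 and 3 all rest at one limit: the limit of > 10000 nM in this assay, at which 3 of the 3 values shown sit. The compounds shown leave open what size of potency, if any, chloro or methoxy changes on the shared core produce in this assay.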